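The compounds below may be only part of what the source reports. "The series", "measured", "known", "first", "only" and "open" are said of these compounds alone.

Measured compounds:
compound 1 `Cn1c(NCc2ccccc2)c(C#N)c2c(N)ncnc21`, 3530 nM
compound 2 `Cn1c(-c2ccccc2)c(C#N)c2c(N)ncnc21`, 483 nM

Both were tested in an assay on isolated protein for inhibition of Leucine-rich repeat serine/threonine-protein kinase 2 variant G2019S (Homo sapiens), read by TR-FRET and LanthaScreen, with stated times of 50 min and 30 min, in the presence of a further agent that is not named here; on this read-out lower numbers stand for stronger inhibition and higher numbers for weaker inhibition. On these two numbers compound 1 stands highest: compound 2 gives the lower number, and the gap between the two lies beyond the usual scatter of repeated measurements, so compound 2 is the stronger inhibitor of this pair. Among the measured compounds shown here, the two differ in how the phenyl group is joined to the shared core, and no single-point step between them is counted here, so only the two values themselves can be compared.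

Compound 3 `Cn1c(NCc2ccccc2F)c(C#N)c2c(N)ncnc21` has not been measured. It differs from compound 1 by fluoro in place of hydrogen on an aromatic carbon. For the measured compounds named here, no measured pair shows this particular change, so its effect in this assay is unknown from the data at hand. A single fluorine added to the ring in this way is a small change, and the step from compound 1 to compound 3 is expected to be modest, most likely not beyond the scatter, with a slight lean toward a lower number: a 1.4-fold lower number from compound 1 to compound 3 (0.13 log units; within the scatter). Compound 3 is therefore estimated at 2600 nM, within a range from 1000 nM to 7000 nM.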

Compound 3, half-maximal inhibitory concentration: 1740 nM
Estimate against measurement, compound 3: 1.5-fold (0.17 log units) above; the range from low to high includes it.
By their numbers in this assay, from the lowest: compound 2; then compound 3; then compound 1.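

In this assay, fluoro in place of hydrogen on the aromatic ring, ortho to a large group, gives a 2.0-fold lower number from compound 1 to compound 3 (0.31 log units; beyond the scatter). Among the compounds shown here, this is the first measured sign that a change on this phenyl ring itself can move the number: the step is modest but lies beyond the scatter, and it goes toward stronger inhibition. So this position accepts a single fluorine with a small gain in this assay, but nothing measured here bears on why the number falls.

Going by these compounds, a single atom at a single place says little about the rest of the ring, so it remains open whether fluoro elsewhere on the ring, or a larger group such as methoxy, trifluoromethyl or an amine at this same place, would take the number further down or back up. On these data alone, it is equally open whether the step carries over to the directly attached phenyl ring of compound 2, since a step measured on one compound need not repeat on another.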